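Swapping the aromatic group on the amide nitrogen

A few compounds are considered here, and "the series" means these few. Any claim that something is new, unique, unknown or untested is made for them only; others in the source may bear on it.

Measured in a functional assay on A549 cells (Homo sapiens) for inhibition, read by MTT assay, with a stated time of 72 h; on this read-out higher numbers stand for weaker inhibition and lower numbers for stronger inhibition:
compound 1 `CCc1ccc(NC(=O)C2CCN(C/C=C/c3ccccc3)CC2)cc1`: 19600 nM
compound 2 `CC(C)c1ccc(NC(=O)C2CCN(C/C=C/c3ccccc3)CC2)cc1`: 9430 nM
compound 3 `O=C(Nc1cccc(C(F)(F)F)c1)C1CCN(C/C=C/c2ccccc2)CC1`: 15600 nM

Compound 2 shares the low end of these numbers with compound 3, the two lying within the scatter of each other. Among the measured compounds shown here, the only clear step is a 2.1-fold lower number from compound 1 to compound 2 (0.32 log units; beyond the scatter), a modest one.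

Compound 4 `O=C(Nc1ccc(F)c(Br)c1)C1CCN(C/C=C/c2ccccc2)CC1` carries a larger change: 3-bromo-4-fluorophenyl in place of 4-isopropylphenyl on an amide-type nitrogen. For the measured compounds named here, no measured step covers this swap directly. The nearest guide is that the three compounds differ only modestly, with compound 3, which bears a trifluoromethyl group, at 15600 nM.

In this assay, the expected change is no step beyond the scatter, an estimated 1.2-fold higher number from compound 2 to compound 4 (0.07 log units; within the scatter). Compound 4 is expected at 11000 nM, with an estimated range of 5000 nM to 24000 nM.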

Compound 4, half-maximal inhibitory concentration: 11700 nM
Compound 4: middle estimate off by 1.1-fold (0.03 log units), on the low side, within the range that was stated.
By their numbers in this assay, from the lowest: compounds 2, 4, 3 and 1 (each within the scatter of the next, the first and the last beyond it).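

In this assay, 3-bromo-4-fluorophenyl in place of 4-isopropylphenyl on the amide-type nitrogen gives a 1.2-fold higher number from compound 2 to compound 4 (0.09 log units; within the scatter) and in place of 4-ethylphenyl gives a 1.7-fold lower number from compound 1 to compound 4 (0.22 log units; within the scatter) and neither step is a real difference. At this position, then, a ring carrying bromine and fluorine reads the same as rings carrying an alkyl group. Still open, as far as these compounds go, is whether an amine or a carboxylic acid on this ring would move the number clearly. Nothing available explains why these different rings read so alike.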